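Swapping Chloro for Methyl on a Thiophene Amine

The source may report more compounds than this note shows. Statements on the series, on what has been measured and on what is new or still open speak of the compounds shown alone.

Of the compounds shown here, three sharing one core have been tested in an ADME assay on Vero cells (Chlorocebus sabaeus) for cytotoxicity, read by MTT assay, with a stated time of 96 h; on this read-out higher numbers stand for lower toxicity in this test and lower numbers for higher toxicity in this test. Compound 1 `COc1cc(NCc2ccc(Cl)s2)ccc1-c1cnco1` gives 53800 nM in this assay, the lowest of the three numbers. Compound 3 `COc1cc(/N=C/C=C/c2ccccc2)ccc1-c1cnco1` gives 105000 nM in this assay, a value within the scatter of that of compound 1, so no order between the two can be stated. Compound 2 `COc1cc(/N=C/c2ccc(F)cc2)ccc1-c1cnco1` gives 325000 nM in this assay, a value that lies beyond the scatter above compound 1. Compound 4 `COc1cc(NCc2ccc(C)s2)ccc1-c1cnco1` has not yet been measured; it differs from compound 1 by methyl in place of chloro on an aromatic carbon. Among the measured compounds shown here, no measured pair shows a change of this kind, so the direction is open, and a step of no size beyond the scatter is expected. Compound 4 is estimated at 60000 nM in this assay, with a range from 25000 nM to 150000 nM, an expected step of a 1.1-fold higher number from compound 1 to compound 4 (0.05 log units; within the scatter).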

Compound 4, half-maximal cytotoxic concentration: 24700 nM
Beside the measured number, compound 4's estimate is 2.4-fold (0.39 log units) above it; measured number outside the range, below it.
By their numbers in this assay, from the lowest: compound 4; then compounds 1 and 3 (each within the scatter of the next); then compound 2.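

Among the compounds shown here, this is the first pair that differs in one place only, and it shows that the group next to the ring sulfur matters in this assay: methyl in place of chloro gives a modest but real drop (a 2.2-fold lower number from compound 1 to compound 4 (0.34 log units; beyond the scatter)), which on this read-out means higher toxicity in this test. A single atom swapped at this position is therefore enough to move the number beyond the scatter. Nothing available explains why the number moves. A single pair cannot show whether a bromo, methoxy or trifluoromethyl group here would follow the same direction. It also leaves open whether the same swap would act alike elsewhere on the molecule.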